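Replacing a phenoxy tail with methoxy on a shared core

The source may hold more compounds than are shown below. What is called first, only, known or untested is meant among the compounds shown, and "the series" means these compounds.

Compound 2 `O=C1N=C(c2ccc3ccccc3c2)S/C1=C\c1ccc(Oc2ccccc2)cc1` gives 60 nM in an assay on PMNL cells for inhibition of Polyunsaturated fatty acid 5-lipoxygenase (Homo sapiens), read by HPLC, with stated times of 15 min and 10 min; a lower number here means a stronger inhibitor, a higher number a weaker inhibitor. Compound 1 `O=C1N=C(c2ccc(Cl)cc2)S/C1=C\c1ccc(Oc2ccccc2)cc1` gives 80 nM in this assay, and the two lie within the scatter of each other. Among the compounds with values here, the only measured step, a 1.3-fold lower number from compound 1 to compound 2 (0.12 log units; within the scatter), concerns the ring on the carbon with a double bond to nitrogen. Compound 3 `COc1ccc(/C=C2\SC(c3ccc4ccccc4c3)=NC2=O)cc1` differs from compound 2 at another place: methyl in place of phenyl on an oxygen on an aromatic ring. Within the data shown here, no measured step touches this oxygen, so the data give no guide to this change. Compound 3 is therefore expected to give about 200 nM, within 60 nM to 700 nM, a step of a 3.3-fold higher number from compound 2 to compound 3 (0.52 log units; beyond the scatter) expected to lean toward a weaker inhibitor.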

Compound 3, half-maximal inhibitory concentration: 80 nM
For compound 3 the middle estimate is 2.5-fold (0.40 log units) above the measured one; the range from low to high includes it.
By their numbers in this assay, from the lowest: compounds 2, 1 and 3 (each within the scatter of the next).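

Replacing phenoxy with methoxy on the shared core gives a 1.3-fold higher number from compound 2 to compound 3 (0.12 log units; within the scatter) in this assay, which stays within the scatter. The phenyl on this oxygen can therefore give way to a methyl, losing a whole aromatic ring, without a measurable change in this pair. As far as these compounds go, whether a longer chain such as butyl, or a carboxylic acid at the end of such a chain, would fit on this oxygen remains open, as does whether methoxy would behave the same with 4-chlorophenyl on the core. Nothing measured here explains why the number holds.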